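Compound 3 to compound 4: fluoro becomes methoxy

A few compounds are considered here, and "the series" means these few. Any claim that something is new, unique, unknown or untested is made for them only; others in the source may bear on it.

Compound 1 `O=S(=O)(Nc1ccc(-c2nc3ccccc3o2)cc1)c1ccc(Cl)s1` gives > 100000 nM as a limit
Compound 2 `C=Cc1ccc(S(=O)(=O)Nc2ccc(-c3nc4ccccc4o3)cc2)cc1` gives > 100000 nM as a limit
Compound 3 `O=S(=O)(Nc1ccc(-c2nc3ccccc3o2)cc1)c1ccc(F)cc1` gives > 100000 nM as a limit

In an ADME assay on HEK293 cells (Homo sapiens) for cytotoxicity, read by resazurin assay, with a stated time of 48 h (on this read-out higher numbers stand for lower toxicity in this test and lower numbers for higher toxicity in this test), compound 3 stands at > 100000 nM and that is a limit, not a number. Compound 4 `COc1ccc(S(=O)(=O)Nc2ccc(-c3nc4ccccc4o3)cc2)cc1` carries one change: methoxy in place of fluoro on an aromatic carbon with methoxy in place of fluoro on an aromatic carbon. The closest measured change is a step that the two limits leave unreadable from compound 2 to compound 3 with fluoro in place of vinyl on an aromatic carbon. The other two, a step that the two limits leave unreadable from compound 1 to compound 2 and a step that the two limits leave unreadable from compound 1 to compound 3, swap the group on the sulfonyl sulfur. No size can be read from any of them, since all three compounds share the limit of > 100000 nM in this assay, at which 3 of the 3 values shown sit, without exception. No step beyond the scatter is therefore expected in this assay, in either direction. The expected change is a number no higher from compound 3 to compound 4 (the limit leaves the size open) with no direction foreseen. Compound 4 is estimated at 100000 nM with an expected range from 50000 nM to 200000 nM here.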

Compound 4, half-maximal cytotoxic concentration: > 100000 nM
Compound 4 gave a limit, no number; the forecaster's own chance of this, stated with the estimate: 85%; the middle value lies on the limit itself.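

No new step can be read from compound 1, compound 2 or compound 3 to compound 4, as all four share a single value that is only a limit: the limit of > 100000 nM in this assay, at which 4 of the 4 values shown sit.

The compounds shown leave open whether these groups differ at all in this assay.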